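Replacing Nitro with Hydroxy on the Shared Core

The source may hold more compounds than are shown below. What is called first, only, known or untested is meant among the compounds shown, and "the series" means these compounds.

In a functional assay on SH-SY5Y cells (Homo sapiens) for cytotoxicity, read by MTT assay, with a stated time of 48 h (on this read-out lower numbers stand for stronger inhibition and higher numbers for weaker inhibition), compound 1 (`COc1ccc(/C=C/C(=O)/C=C/c2nc3ccccc3n2C)cc1O`) gives 4800 nM, compound 2 (`COc1ccc(/C=C/C(=O)/C=C/c2nc3cc(Cl)ccc3n2C)cc1O`) gives 4800 nM and compound 3 (`COc1ccc(/C=C/C(=O)/C=C/c2nc3cc([N+](=O)[O-])ccc3n2C)cc1O`) gives 8100 nM. Compound 3 therefore stands within the usual scatter of both other compounds. Compound 4 (`COc1ccc(/C=C/C(=O)/C=C/c2nc3cc(O)ccc3n2C)cc1O`) carries hydroxy in place of nitro on an aromatic carbon. For the measured compounds named here, three measured steps bear on this change: no change at the digits printed from compound 1 to compound 2 (within the scatter), a 1.7-fold higher number from compound 1 to compound 3 (0.23 log units; within the scatter) and a 1.7-fold higher number from compound 2 to compound 3 (0.23 log units; within the scatter). Going by the values given here, all three stay within the scatter, although no measured compound yet carries hydroxy at this place. No step beyond the scatter is therefore expected in this assay. The expected step is a 1.6-fold lower number from compound 3 to compound 4 (0.21 log units; within the scatter). For compound 4 the estimated value is 5000 nM, with an expected range of 2500 nM to 10000 nM.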

Compound 4, half-maximal inhibitory concentration: 4600 nM
Estimate against measurement, compound 4: 1.1-fold (0.04 log units) above; measured number inside the range.
By their numbers in this assay, from the lowest: compounds 4, 1, 2 and 3 (each within the scatter of the next).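

Hydroxy, with one hydrogen-bond donor where nitro has none, also stays within the scatter in this assay: a 1.8-fold lower number from compound 3 to compound 4 (0.25 log units; within the scatter), a 1.0-fold lower number from compound 2 to compound 4 (0.02 log units; within the scatter) and a 1.0-fold lower number from compound 1 to compound 4 (0.02 log units; within the scatter). Hydrogen, chloro, nitro and hydroxy on this aromatic carbon therefore give numbers that cannot be told apart from one another in this read-out. The data shown offer no explanation for this. Going by these compounds, whether an amine, a carboxylic acid or a longer chain at this place would give a step beyond the scatter remains open.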